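The source may hold more compounds than are shown below. What is called first, only, known or untested is meant among the compounds shown, and "the series" means these compounds.

Values measured so far in a functional assay on blood (Homo sapiens), with a stated time of 60 min, in the presence of a further agent that is not named here; on this read-out higher numbers stand for an effect only at larger amounts of compound and lower numbers for an effect already at smaller amounts

- Compound 1 `Nc1ccccc1NC(=O)C1(S(=O)(=O)c2ccc(Oc3ccc(OC(F)(F)F)cc3)cc2)CCC2(CCNCC2)C1` gives 900 nM
- Compound 2 `CNC(=O)NC(=O)C1(S(=O)(=O)c2ccc(Oc3ccc(OC(F)(F)F)cc3)cc2)CCC2(CCNCC2)C1` gives < 400 nM (a limit)
- Compound 3 `Nc1ccccc1NC(=O)C1(S(=O)(=O)c2ccc(NC3CCCCC3)cc2)CCC2(CCNCC2)C1` gives <= 400 nM (a limit)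

Within the data shown here, compound 1 holds the only exact number of the three, and it has the highest value, since both of the others are limits that sit lower. Compound 4 `Nc1ccccc1NC(=O)C1(S(=O)(=O)c2ccc(Oc3ccc(OC(F)(F)F)cc3)c(Cl)c2)CCC2(CCNCC2)C1` differs from compound 1 by one small edit (chloro in place of hydrogen on an aromatic carbon): chloro in place of hydrogen on an aromatic carbon, ortho to a 4-(trifluoromethoxy)phenoxy group.

Among the measured compounds shown here, no measured step adds a chloro. Two steps offer indirect guidance. Methylcarbamoyl in place of 2-aminophenyl gave an at least 2.2-fold lower number from compound 1 to compound 2 (0.35 log units; beyond the scatter), and cyclohexylamino in place of 4-(trifluoromethoxy)phenoxy gave an at least 2.2-fold lower number from compound 1 to compound 3 (0.35 log units; beyond the scatter). The second step is the closer guide, as it alters the group that the chloro sits ortho to, but it replaces that whole group. A single added chloro is a far smaller edit, so no step beyond the scatter is expected in this assay, and no direction is firmly favoured. The estimated change is a 1.3-fold lower number from compound 1 to compound 4 (0.11 log units; within the scatter). For compound 4 the expected value is 700 nM, within an estimated range of 280 nM to 1800 nM.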

Compound 4, half-maximal effective concentration: 3700 nM
Compound 4: middle estimate off by 5.3-fold (0.72 log units), on the low side; the measured number lies above the stated range.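

In this assay adding one chloro gives a 4.1-fold higher number from compound 1 to compound 4 (0.61 log units; beyond the scatter) and so shows that this place on the aromatic ring responds to a change of a single heavy atom. The earlier steps replaced whole groups, and both ran toward lower numbers; this is the first step shown that runs toward a higher number, and it comes from a chloro ortho to a 4-(trifluoromethoxy)phenoxy group. Nothing given here explains why the number rises.

From the compounds shown here alone, whether a fluoro, a methyl or an amine at the same place would shift the number in the same direction stays open. So does whether a chloro here would give a step of similar size on compound 2, with its methylcarbamoyl group.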